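Swapping an Aryl Ether for a Benzoylmethyl Thioether

This account rests on a few compounds, and the source may have more. Where it says the series, first, only, none or still open, it means among the compounds named here.

Compound 1, `COC(=O)c1cc2c(F)c(F)c(Oc3ccccc3Br)c(F)c2s1`: in an ADME assay on MCF7 cells (Homo sapiens) for inhibition (on this read-out higher numbers stand for weaker inhibition and lower numbers for stronger inhibition), compound 1 gives > 25000 nM, which is a limit of the assay and not a number.
Compound 2, `COC(=O)c1cc2c(F)c(F)c(Sc3ccccc3Br)c(F)c2s1`: in this assay compound 2 gives > 25000 nM, again a limit of the assay.
Compound 3, `O=C(c1ccccc1)c1cc2c(F)c(F)c(Oc3ccccc3Br)c(F)c2s1`: in this assay compound 3 gives > 25000 nM, also a limit of the assay.

Compound 3 therefore stands at the edge of what this assay can report: it sits at the limit of > 25000 nM in this assay, at which 3 of the 3 values shown sit, together with the other two compounds. The two measured steps, a step that the two limits leave unreadable from compound 1 to compound 2 and a step that the two limits leave unreadable from compound 1 to compound 3, run from one limit to another, so their size cannot be read and they cannot show whether either change mattered.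

The unmeasured compound 4, `O=C(CSc1c(F)c(F)c2cc(C(=O)c3ccccc3)sc2c1F)c1ccccc1`, differs from compound 3 by the change ((benzoylmethyl)sulfanyl in place of 2-bromophenoxy on an aromatic carbon). For the measured compounds named here, no measured step touches this kind of change, and the two steps that exist give no readable size. Going by the values given here, the only guidance is that every compound measured so far has stayed at the limit. On that basis compound 4 is expected to give 30000 nM in this assay, with a range from 8000 nM to 120000 nM. Compound 4 is thus expected to show a step that the limit leaves unreadable from compound 3 to compound 4, most likely ending once more at the limit rather than at a number.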

Compound 4, half-maximal inhibitory concentration: > 50000 nM
Compound 4: a limit, no number; the forecaster's own chance of this, stated with the estimate: 75%; middle value at least 1.6-fold (0.22 log units) from the limit.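

In this assay, compound 4 gives > 50000 nM, which is a limit of the assay and not a number. For the compounds shown here, compound 3 also stands at a limit, so no step between compound 3 and compound 4 can be read. The compounds shown leave open whether swapping 2-bromophenoxy for (benzoylmethyl)sulfanyl changes inhibition at all.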